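One More Chloro on the Carbamate Aryl Ring

The source may report more compounds than this note shows. Statements on the series, on what has been measured and on what is new or still open speak of the compounds shown alone.

Three carbamates that share one core have been tested in a functional assay on PANC-1 cells (Homo sapiens) for inhibition, read by MTT assay, with a stated time of 24 h, tested at 10 uM; on this read-out lower numbers stand for less inhibition and higher numbers for more inhibition at the one concentration tested (going by the name of the read-out). Compound 1 `COc1ccccc1NC(=O)Oc1cc(=O)n(CCCO)c2c1CC(C/C=C(\C)CCC=C(C)C)C(C)(C)C2` gives 53%. Compound 2 `CC(C)=CCC/C(C)=C/CC1Cc2c(OC(=O)Nc3ccc(F)cc3F)cc(=O)n(CCCO)c2CC1(C)C` gives 33.7%, and compound 3 `CC(C)=CCC/C(C)=C/CC1Cc2c(OC(=O)Nc3ccc(Cl)cc3)cc(=O)n(CCCO)c2CC1(C)C` gives 47.2%. Compound 3 therefore stands second highest of the three: its gap to compound 1, a number 5.8 percentage points lower from compound 1 to compound 3 (within the scatter), falls within the usual scatter, while a number 13.5 percentage points higher from compound 2 to compound 3 (beyond the scatter) is beyond it. Compound 4 `CC(C)=CCC/C(C)=C/CC1Cc2c(OC(=O)Nc3ccc(Cl)c(Cl)c3)cc(=O)n(CCCO)c2CC1(C)C` is the unmeasured neighbour of compound 3. The change is chloro in place of hydrogen on an aromatic carbon. Among the measured compounds shown here, no measured step swaps a hydrogen for a chloro, so none bears directly on this change. The steps that exist all exchange the whole aryl group: a number 19.3 percentage points lower from compound 1 to compound 2 (beyond the scatter) lost ground, a number 5.8 percentage points lower from compound 1 to compound 3 (within the scatter) stayed within the scatter, and a number 13.5 percentage points higher from compound 2 to compound 3 (beyond the scatter) gained modestly. Exchanges of this ring have thus moved the read-out by modest amounts at most, and a single added chloro is a smaller structural change than any of them. The expected step for compound 4 is therefore a number 2.8 percentage points higher from compound 3 to compound 4 (within the scatter), no more than the scatter. The estimate for compound 4 in this assay is 50%, with a range from 35% to 65%.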

Compound 4, a percentage reported as inhibition, at one concentration (the size of the read-out at that concentration, not a potency): 20%
Estimate against measurement, compound 4: 30 percentage points above, and the stated range ends above it.
By their numbers in this assay, from the lowest: compound 4; then compound 2; then compounds 3 and 1 (each within the scatter of the next).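

In this assay, chloro in place of hydrogen on the aromatic carbon ortho to the existing chloro group gives a number 27.2 percentage points lower from compound 3 to compound 4 (beyond the scatter), so one added heavy atom at this position shifts the read-out towards less inhibition by more than the usual scatter, a step of the same modest class as some exchanges of the whole aryl group. Among the compounds shown here, the 3,4-dichlorophenyl group also falls below the other two aryl groups, with a number 13.7 percentage points lower from compound 2 to compound 4 (beyond the scatter) and a number 33 percentage points lower from compound 1 to compound 4 (beyond the scatter), the latter being the only large step in this set, which leaves compound 4 with the lowest number of the four at the one concentration tested. The data shown offer no explanation for why this added chloro lowers the number.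

On these data alone, this is a single example of the change, so it remains open whether the drop depends on chloro itself or on any group at this carbon. A methyl or a nitrile on the same carbon of the 4-chlorophenyl ring would help separate those two readings, and a full concentration series would show whether the gap also holds as a difference in potency.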